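Amide variation on the shared core, toward compound 3

This account rests on a few compounds, and the source may have more. Where it says the series, first, only, none or still open, it means among the compounds named here.

Compound 1 `C#CCNC(=O)/C=C/c1c(/C=C/c2ccc(OC)cc2)cc(OC)cc1OC` carries a propargylamino group on the carbonyl carbon. In a functional assay on B16-F10 cells (Mus musculus) for inhibition, read by MTT assay, with a stated time of 48 h (on this read-out lower numbers stand for stronger inhibition and higher numbers for weaker inhibition), compound 1 gives 8280 nM. Compound 2 `COc1ccc(/C=C/c2cc(OC)cc(OC)c2/C=C/C(=O)N2CCC(c3ccccc3)CC2)cc1` carries a 4-phenylpiperidin-1-yl group at that carbon; in this assay compound 2 gives 9180 nM. The step of a 1.1-fold higher number from compound 1 to compound 2 (0.04 log units; within the scatter) is within the scatter. Among the compounds with values here, compound 2 thus stands at one of two numbers that cannot be told apart from each other, with compound 1 as its only neighbour.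

Compound 3 `CCCCCN(CCCCC)C(=O)/C=C/c1c(/C=C/c2ccc(OC)cc2)cc(OC)cc1OC` differs from compound 2 by dipentylamino in place of 4-phenylpiperidin-1-yl on a carbonyl carbon. Within the data shown here, the only measured step at the same carbonyl carbon is a 1.1-fold higher number from compound 1 to compound 2 (0.04 log units; within the scatter), and it shows that exchanging one amine substituent for another of quite different shape left the read-out essentially where it was. On that single precedent, a further exchange at the same place, dipentylamino in place of 4-phenylpiperidin-1-yl, is expected to give no step beyond the scatter in this assay. For compound 3 the expected value in this assay is 9000 nM, with a range of 4000 nM to 20000 nM. This corresponds to an expected step of a 1.0-fold lower number from compound 2 to compound 3 (0.01 log units; within the scatter).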

Compound 3, half-maximal inhibitory concentration: 9270 nM
Compound 3: middle estimate off by 1.0-fold (0.01 log units), on the low side; low and high end bracket the measured number.
By their numbers in this assay, from the lowest: compounds 1, 2 and 3 (each within the scatter of the next).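

Working notes on the amide position: in this assay, the exchange of 4-phenylpiperidin-1-yl, with its two six-membered rings, for dipentylamino, with no ring, gives a 1.0-fold higher number from compound 2 to compound 3 (0.00 log units; within the scatter) and so leaves the read-out unresolved. The earlier pair kept a ring-free group at one end and a ring-bearing group at the other; this step adds that two large amine groups, one with rings and one with open chains, cannot be told apart on this carbonyl carbon. The step of a 1.1-fold higher number from compound 1 to compound 3 (0.05 log units; within the scatter) places dipentylamino and the much smaller propargylamino within the scatter too, so the three amine groups shown form no order, and none of them stands out at this position.

What the compounds shown leave open is whether a group of another kind on the carbonyl carbon, such as a chain ending in a carboxylic acid or in a primary amine, would move the number beyond the scatter. Also open, on these data alone, is whether changing the methoxy groups on the shared core would do so, and nothing on hand explains why the read-out stays this flat.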